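The source may hold more compounds than are shown below. What is called first, only, known or untested is meant among the compounds shown, and "the series" means these compounds.

Measured so far:
Compound 1 (`CC1=CC[C@@H]([C@@](C)(O)CCCC(C)(C)NC(=S)N/N=C\c2ccccc2)CC1`): 43600 nM
Compound 2 (`CC1=CC[C@@H]([C@@](C)(O)CCCC(C)(C)NC(=S)N/N=C\c2ccc([N+](=O)[O-])cc2)CC1`): > 100000 nM

For the measured compounds named here, compound 1 is the only compound here with a number in a functional assay on OVCAR-3 cells (Homo sapiens) for cytotoxicity, read by sulforhodamine B assay; on this read-out higher numbers stand for lower toxicity in this test and lower numbers for higher toxicity in this test; in this assay compound 1 gives 43600 nM. Compound 2 reaches only a limit of the assay, > 100000 nM. Going by the values given here, the single measured step between the two, an at least 2.2-fold higher number from compound 1 to compound 2 (0.36 log units; beyond the scatter), runs toward that limit, as the evidence marks: the limit of > 100000 nM in this assay, at which 1 of the 2 values shown sits.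

Compound 3 (`CC1=CC[C@@H]([C@@](C)(O)CCCC(C)(C)NC(=S)N/N=C\c2ccccc2Cl)CC1`) differs from compound 1 by chloro in place of hydrogen on an aromatic carbon. Among the compounds with values here, the one measured step on the same ring, an at least 2.2-fold higher number from compound 1 to compound 2 (0.36 log units; beyond the scatter), concerns a different group at a different place, so it bears on the chloro change only loosely. Compound 3 is therefore expected to land at about 40000 nM in this assay, within a range from 15000 nM to 100000 nM. For compound 3 the expected step of a 1.1-fold lower number from compound 1 to compound 3 (0.04 log units; within the scatter) lies within the scatter.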

Compound 3, concentration lethal to 50% of the cells: > 100000 nM
Compound 3: a limit, no number (the forecaster's own chance of this, stated with the estimate: 25%); middle value at least 2.5-fold (0.39 log units) away from the limit.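

In this assay, chloro in place of hydrogen on an aromatic carbon, ortho to a large group, gives an at least 2.2-fold higher number from compound 1 to compound 3 (0.36 log units; beyond the scatter). The move away from compound 1 is therefore not confined to the nitro group of compound 2, since a single chlorine at a different place on the ring also carries the read-out beyond the scatter. Compound 3 gives a limit and not a number, so its step from compound 2 cannot be read, and the true size of the chloro change stays unknown: the limit of > 100000 nM in this assay, at which 2 of the 3 values shown sit.

Going by these compounds, what remains open is whether any substituent on this ring would have the same result, or whether an amine or a methoxy group in the same place would stay near compound 1. On these data alone, it is also open how chloro would behave at the place the nitro group holds in compound 2.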